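A few compounds are considered here, and "the series" means these few. Any claim that something is new, unique, unknown or untested is made for them only; others in the source may bear on it.

Measured compounds, with their values in a functional assay, read by spectrophotometry, with a stated time of 3 min; a higher number here means a weaker inhibitor, a lower number a stronger inhibitor:

compound 1 `O=c1[nH]c2ccccc2cc1/C=N/O`, compound 1 gives 31800 nM
compound 2 `Cc1ccc2[nH]c(=O)c(/C=N/O)cc2c1`, compound 2 gives 38900 nM
compound 3 `O=C(O)c1ccc(/N=C/c2cc3ccccc3[nH]c2=O)cc1`, compound 3 gives 438000 nM

Compound 1 and compound 2 share a core; compound 2 carries methyl in place of hydrogen on an aromatic carbon and the step of a 1.2-fold higher number from compound 1 to compound 2 (0.09 log units; within the scatter) follows. Compound 3 carries a different core; how the core of compound 3 differs from that of compound 1 is not broken down here. In this assay compound 3 stands highest of the three, its value well beyond the scatter from those of compound 1 and compound 2.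

Compound 4 `Cc1ccc2[nH]c(=O)c(/C=N/c3ccc(C(=O)O)cc3)cc2c1` is not yet measured. It carries methyl in place of hydrogen on an aromatic carbon, the same change that leads from compound 1 to compound 2, at the same place on the ring. The step of a 1.1-fold higher number from compound 3 to compound 4 (0.04 log units; within the scatter) is expected to be of the same small size, because the earlier step of a 1.2-fold higher number from compound 1 to compound 2 (0.09 log units; within the scatter) stayed within the scatter. Compound 4 is thus expected to give about 480000 nM, between 200000 nM and 1100000 nM.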

Compound 4, half-maximal inhibitory concentration: 222000 nM
Compound 4: middle estimate off by 2.2-fold (0.33 log units), on the high side; measured number inside the range.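

In this assay, methyl in place of hydrogen on an aromatic carbon gives a 2.0-fold lower number from compound 3 to compound 4 (0.30 log units; within the scatter). The step on the core of compound 3 cannot be told apart from the one on the core of compound 1: the same change on two cores in this assay, a 1.2-fold higher number (0.09 log units; within the scatter) from compound 1 to compound 2 and a 2.0-fold lower number (0.30 log units; within the scatter) from compound 3 to compound 4, 2.4-fold (0.38 log units) apart, within the scatter of two such steps. Across these two cores, the change thus stays within the scatter both times, but two pairs do not show how it would behave on any other core, nor do they give it a size beyond that scatter.

From the compounds shown here alone, it remains open whether a larger group at this place, such as ethyl or methoxy, or a different one, such as chlorine or an amine, would move the number beyond the scatter. Methyl on another aromatic carbon of the ring also remains open.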